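The source may report more compounds than this note shows. Statements on the series, on what has been measured and on what is new or still open speak of the compounds shown alone.

In a functional assay on MCF7 cells (Homo sapiens) for inhibition, read by MTT assay, with a stated time of 72 h (a higher number here means a weaker inhibitor, a lower number a stronger inhibitor), the three measured compounds gave the following values:
compound 1 `COc1cc(NC(C)CCCNC(=O)Nc2ccc(F)cc2)c2ncccc2c1`, 26000 nM;
compound 2 `COc1cc(NC(C)CCCNC(=O)NNC(=O)Nc2cccc(F)c2)c2ncccc2c1`, 150 nM;
compound 3 `COc1cc(NC(C)CCCNC(=O)Nc2ccc(C(F)(F)F)cc2)c2ncccc2c1`, 1900 nM.

Compound 2 gives the lowest number of the three. Its core differs from that of compound 1 by ((3-fluorophenyl)carbamoyl)amino in place of 4-fluorophenyl on an amide-type nitrogen, and this change made a 170-fold lower number from compound 1 to compound 2 (2.24 log units; beyond the scatter). Within the core of compound 1, the change trifluoromethyl in place of fluoro on an aromatic carbon made a 14-fold lower number from compound 1 to compound 3 (1.14 log units; beyond the scatter). Between compound 2 and compound 3 the step is a 13-fold higher number from compound 2 to compound 3 (1.10 log units; beyond the scatter).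

Compound 4 `COc1cc(NC(C)CCCNC(=O)NNC(=O)Nc2cccc(C(F)(F)F)c2)c2ncccc2c1` has not been measured. It differs from compound 2 by trifluoromethyl in place of fluoro on an aromatic carbon. Within the data shown here, this is the same kind of change as the one from compound 1 to compound 3, though not the same: there the group sits para to a large group, here it sits meta to a large group, and the core is that of compound 2 rather than compound 1.

On this basis compound 4 is expected to show a 3.8-fold lower number from compound 2 to compound 4 (0.57 log units; beyond the scatter) in this assay, resting on the step of a 14-fold lower number from compound 1 to compound 3 (1.14 log units; beyond the scatter) seen for compound 3. The expectation is held more modest, the place and the core differing from those of that step. The estimated value for compound 4 is 40 nM, with a range from 10 nM to 160 nM.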

Compound 4, half-maximal inhibitory concentration: 190 nM
Estimate against measurement, compound 4: 4.8-fold (0.68 log units) below, outside the stated range (above it).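

In this assay, putting trifluoromethyl in place of fluoro on the core of compound 2 gave a 1.3-fold higher number from compound 2 to compound 4 (0.10 log units; within the scatter), so this change, with the group meta to a large group, leaves the reading on this core within the scatter. Among these compounds, the result on the core of compound 1 therefore did not carry over to the core of compound 2, and the two steps differ clearly: the same change on two cores in this assay, a 14-fold lower number (1.14 log units; beyond the scatter) from compound 1 to compound 3 and a 1.3-fold higher number (0.10 log units; within the scatter) from compound 2 to compound 4, 17-fold (1.24 log units) apart, beyond the scatter of two such steps This does not show that the core alone sets the size of the step, since the first pair carries the change on 4-fluorophenyl and the second on 3-fluorophenyl, so place and core change together.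

The compounds shown leave open what 4-(trifluoromethyl)phenyl would give on the core of compound 2 and what 3-(trifluoromethyl)phenyl would give on the core of compound 1, the two cases that would separate place from core. They also leave open how a chloro or a nitrile in the same place would behave on either core.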